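The source may report more compounds than this note shows. Statements on the series, on what has been measured and on what is new or still open speak of the compounds shown alone.

Measured so far:
compound 1, `Cc1cc(NC(=O)Nc2ccc(F)cc2)c2ccccc2n1`: > 25000 nM
compound 2, `Cc1cc(NC(=O)Nc2ccc(N(C)C)cc2)c2ccccc2n1`: > 25000 nM

In an ADME assay on Raji cells (Homo sapiens) for cytotoxicity, with a stated time of 72 h (on this read-out lower numbers stand for an effect already at smaller amounts and higher numbers for an effect only at larger amounts of compound), compound 1 reaches only the limit of the test, > 25000 nM, and no number within its range. Compound 2 likewise gives only a limit, > 25000 nM. For the measured compounds named here, the one measured step, a step that the two limits leave unreadable from compound 1 to compound 2, is unreadable because of the limit of > 25000 nM in this assay, at which 2 of the 2 values shown sit. Going by the values given here, compound 1 thus stands at the limit, and nothing among the measured values tells how far beyond it the true number lies.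

Compound 3, `Cc1cc(NC(=O)Nc2ccccc2F)c2ccccc2n1`, differs from compound 1 by 2-fluorophenyl in place of 4-fluorophenyl on an amide-type nitrogen. Among the compounds with values here, no measured step covers a change of this kind, and the one step that is known is unreadable, so the measured data give no size or direction for the expected step in this assay. Compound 3 is therefore expected to sit at 30000 nM, with a range from 10000 nM to 100000 nM, most likely reported again only as a limit. The expected step is a step that the limit leaves unreadable from compound 1 to compound 3, which is no change beyond the scatter.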

Compound 3, half-maximal effective concentration: > 25000 nM
Compound 3 ended at the assay's limit (the forecaster's own chance of this, stated with the estimate: 85%); the middle value does not contradict the limit.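

The step from compound 1 to compound 3 cannot be read, and neither can any other step among compounds 1, 2 and 3, because each gives only a limit: the limit of > 25000 nM in this assay, at which 3 of the 3 values shown sit.

The compounds shown leave open whether 2-fluorophenyl and 4-fluorophenyl differ at all in this assay, since the true values remain unknown.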